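This account rests on a few compounds, and the source may have more. Where it says the series, first, only, none or still open, it means among the compounds named here.

For the measured compounds named here, compound 2, whose structure is `COc1cc(/C=N/c2nnc(SCc3c[se]c(-c4ccccc4)n3)s2)ccc1O`, gives 15000 nM in a functional assay on MCF7 cells (Homo sapiens) for antiproliferative activity, read by CCK-8 assay (a lower number here means a stronger inhibitor, a higher number a weaker inhibitor), the lower of the two numbers measured so far. Going by the values given here, its only neighbour in the set is compound 1, `C(=N/c1nnc(SCc2c[se]c(-c3ccccc3)n2)s1)\c1ccccc1`, which in this assay gives 25600 nM; the step of a 1.7-fold lower number from compound 1 to compound 2 (0.23 log units; within the scatter) stays within the scatter, so the two compounds cannot be ranked against each other on these data.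

Compound 3, `O=[N+]([O-])c1ccc(/C=N/c2nnc(SCc3c[se]c(-c4ccccc4)n3)s2)cc1`, carries the change (4-nitrophenyl in place of 4-hydroxy-3-methoxyphenyl on a carbon with a double bond to nitrogen). Among the compounds with values here, the one measured step that bears on it is a 1.7-fold lower number from compound 1 to compound 2 (0.23 log units; within the scatter), the only other exchange of the aryl group on the carbon with a double bond to nitrogen, and that exchange moved the number by less than the scatter. On that single precedent, the exchange for 4-nitrophenyl is expected to leave the number close to where compound 2 stands, with a 1.3-fold higher number from compound 2 to compound 3 (0.12 log units; within the scatter) expected to be no larger than the scatter. Compound 3 is therefore estimated at 20000 nM in this assay, with a range from 7000 nM to 60000 nM.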

Compound 3, half-maximal inhibitory concentration: 49100 nM
The estimate for compound 3 lay 2.5-fold (0.39 log units) below the measured number, within the range that was stated.
By their numbers in this assay, from the lowest: compounds 2, 1 and 3 (each within the scatter of the next, the first and the last beyond it).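

In this assay, for the compounds shown here, the exchange of 4-hydroxy-3-methoxyphenyl for 4-nitrophenyl on the carbon with a double bond to nitrogen gives the first step at this position that lies beyond the scatter, a 3.3-fold higher number from compound 2 to compound 3 (0.51 log units; beyond the scatter), which shows that the aryl group here can shift the number, though only modestly. Nitro in place of hydrogen on an aromatic carbon gives a 1.9-fold higher number from compound 1 to compound 3 (0.28 log units; within the scatter), which stays within the scatter, so the unsubstituted phenyl of compound 1 cannot be ranked against either substituted ring and only compound 2 and compound 3 are separated from each other. Nothing available explains the separation between compound 2 and compound 3.

The compounds shown leave open whether a lone hydroxy or a lone methoxy group on the phenyl ring would stay level with compound 2 or with compound 3. They also leave open where an amine or a carboxylic acid in place of the nitro group would fall, and whether any such group could bring the number clearly below that of compound 2.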